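Series notes: aldehyde dehydrogenase 1A1 inhibition, benzylic variation

This account rests on a few compounds, and the source may have more. Where it says the series, first, only, none or still open, it means among the compounds named here.

Measured compounds:
compound 1 `CCn1c(CN2CCN(C(=O)C3CC3)CC2)nc2ccccc21`: 20.8%
compound 2 `Cc1cccc(Cn2c(OC3CCN(C(=O)c4ccco4)CC3)nc3ccccc32)c1`: 68.3%
compound 3 `Cc1cccc(Cn2c(CN3CCN(C(=O)c4ccc(C(F)(F)F)cc4)CC3)nc3ccccc32)c1`: 22.9%

In an assay on isolated protein for inhibition of aldehyde dehydrogenase 1A1 (Homo sapiens), read by spectrophotometry, tested at 10 uM (a lower number here means less inhibition, a higher number more inhibition at the concentration tested (going by the name of the read-out)), compound 1 gives 20.8%, the lowest of the three numbers. Compound 3 gives 22.9%, a value within the scatter of compound 1, so no order between these two can be read. Going by the values given here, compound 2 gives 68.3%, which lies beyond the scatter above compound 1; no single-point step to compound 2 exists, so only the two values themselves are compared.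

Compound 4 `O=C(C1CC1)N1CCN(Cc2nc3ccccc3n2Cc2ccc(Cl)cc2)CC1` has not been measured. It differs from compound 1 in one place: 4-chlorophenyl in place of methyl on a saturated chain carbon bound to an aromatic nitrogen. Cut one bond further out, the same difference reads ethyl to 4-chlorobenzyl.

Among the compounds with values here, no step between measured compounds is given for this kind of change. Compound 3, which also carries a benzyl group on the aromatic nitrogen, gives 22.9%, within the scatter of compound 1, so a larger group on that saturated chain carbon bound to the aromatic nitrogen has not by itself shown a shift beyond the scatter. The expectation for compound 4 is therefore a step of a number 7.2 percentage points higher from compound 1 to compound 4 (within the scatter) that is small and may not exceed the scatter, with the direction uncertain and a slight lean upward.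

The estimate for compound 4 in this assay is 28%, with a range from 10% to 50%.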

Compound 4, a percentage reported as inhibition, at one concentration (the size of the read-out at that concentration, not a potency): 56.6%
For compound 4 the middle estimate is 28.6 percentage points below the measured one, outside the stated range (above it).
By their numbers in this assay, from the lowest: compounds 1 and 3 (each within the scatter of the next); then compound 4; then compound 2.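

In this assay, going by these compounds alone, 4-chlorophenyl in place of methyl on a saturated chain carbon bound to an aromatic nitrogen gives a number 35.8 percentage points higher from compound 1 to compound 4 (beyond the scatter) and is the first single-place step. With the rest of compound 1 held fixed, this position is therefore shown to respond to substitution, which the earlier compounds could not show because each pair among them differs in more than one place. Nothing available explains the size of this step.

From the compounds shown here alone, whether the step comes from the aromatic ring or from its chlorine stays open, and a plain benzyl, a 4-fluorobenzyl or a longer 2-phenylethyl chain at this position, each paired with compound 1, would separate those readings. Also open, going by these compounds, is whether the step carries over to amides other than the cyclopropyl carbonyl one, since compound 3 differs from compound 4 in more than one place and cannot answer this, whereas a pair sharing a benzoyl or furan-2-carbonyl amide and differing only in ethyl or 4-chlorobenzyl could.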